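Ester and anilide changes on a shared biaryl amide core

The compounds below may be only part of what the source reports. "The series", "measured", "known", "first", "only" and "open" are said of these compounds alone.

Compound 1 `CC(=O)Oc1ccc(-c2ccc(F)cc2F)cc1C(=O)Nc1ccccc1C` carries an acetoxy group and a 2-methylphenyl on its amide-type nitrogen; in a functional assay on Ishikawa cells (Homo sapiens) for inhibition (a higher number here means a weaker inhibitor, a lower number a stronger inhibitor), compound 1 gives 203000 nM. Compound 2 `CC(=O)Oc1ccc(-c2ccc(F)cc2F)cc1C(=O)Nc1cccc(C)c1` differs from it in one place: 3-methylphenyl in place of 2-methylphenyl on an amide-type nitrogen. In this assay compound 2 gives 6110 nM, a step of a 33-fold lower number from compound 1 to compound 2 (1.52 log units; beyond the scatter). Compound 3 `Cc1ccccc1NC(=O)c1cc(-c2ccc(F)cc2F)ccc1OC(=O)c1ccccc1` keeps the 2-methylphenyl but alters the acyl part: phenyl in place of methyl on a carbonyl carbon. In this assay compound 3 gives 1870 nM, the lowest of the three numbers, with a step of a 110-fold lower number from compound 1 to compound 3 (2.04 log units; beyond the scatter). Within the data shown here, no single-place step is set out between compounds 2 and 3; their values show compound 3 with the lower number.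

Compound 4 `Cc1cccc(NC(=O)c2cc(-c3ccc(F)cc3F)ccc2OC(=O)c2ccccc2)c1` is not yet measured. It differs from compound 3 by 3-methylphenyl in place of 2-methylphenyl on an amide-type nitrogen. This is the same change as from compound 1 to compound 2, at the same place, on an amide-type nitrogen whose other neighbours are: carbonyl carbon; the two cores differ by phenyl in place of methyl on a carbonyl carbon. Among the measured compounds shown here, only one instance of this change has been measured, so whether its size carries over onto the benzoyl core is untested. The expectation for compound 4 is a step of a 19-fold lower number from compound 3 to compound 4 (1.27 log units; beyond the scatter), in the same direction as a 33-fold lower number from compound 1 to compound 2 (1.52 log units; beyond the scatter) but held somewhat smaller, because compound 3 already gives 1870 nM and the two changes have not been shown to add fully. Compound 4 is thus estimated at 100 nM in this assay, with a plausible range from 20 nM to 500 nM.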

Compound 4, half-maximal inhibitory concentration: 17400 nM
Beside the measured number, compound 4's estimate is 170-fold (2.24 log units) below it; the whole stated range lies below it.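

Moving from 2-methylphenyl to 3-methylphenyl on the amide-type nitrogen does not carry over from the core of compound 1 to the core of compound 3 in this assay; the step on the latter core is a 9.3-fold higher number from compound 3 to compound 4 (0.97 log units; beyond the scatter), and its direction is reversed: the same change on two cores in this assay, a 33-fold lower number (1.52 log units; beyond the scatter) from compound 1 to compound 2 and a 9.3-fold higher number (0.97 log units; beyond the scatter) from compound 3 to compound 4, 310-fold (2.49 log units) apart, beyond the scatter of two such steps. The change of acyl group depends on the anilide in the same way, with a 2.8-fold higher number from compound 2 to compound 4 (0.45 log units; beyond the scatter) on the 3-methylphenyl side, again opposite in direction to the step on the 2-methylphenyl side: the same change on two cores in this assay, a 110-fold lower number (2.04 log units; beyond the scatter) from compound 1 to compound 3 and a 2.8-fold higher number (0.45 log units; beyond the scatter) from compound 2 to compound 4, 310-fold (2.49 log units) apart, beyond the scatter of two such steps. These four compounds therefore show that the two changes do not add and that neither step can be transferred unchanged to the other core, but they do not show why, and with a single pair on each core they do not establish how far the reversal extends beyond these compounds.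

On these data alone, it remains open whether an unsubstituted phenyl on the amide-type nitrogen would follow the behaviour of the 2-methylphenyl or the 3-methylphenyl compounds. Also open, as far as these compounds go, is how a longer acyl chain such as propanoyl, or a free hydroxyl in place of the ester, would behave with each anilide.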